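Series notes: removing the aryl methyl of compound 2

A few compounds are considered here, and "the series" means these few. Any claim that something is new, unique, unknown or untested is made for them only; others in the source may bear on it.

Compound 2 `Cc1ccc(/C=N/NC(=N)NO)cc1` has been assessed in an ADME assay on HeLa cells (Homo sapiens) for cytotoxicity; a higher number here means that more compound is tolerated, a lower number that less compound is tolerated. There compound 2 gives > 100000 nM, which is a limit of the assay and not a number. Compound 1 `N=C(NO)N/N=C/c1ccccc1Cl` likewise gives > 100000 nM, also a limit. Both values sit at the limit of > 100000 nM in this assay, at which 2 of the 2 values shown sit. Compound 3 `N=C(NO)N/N=C/c1ccccc1` differs from compound 2 by hydrogen in place of methyl on an aromatic carbon. Going by the values given here, no step between measured compounds is available, so no shift beyond the scatter is expected in this assay in either direction. Compound 3 is expected at 100000 nM, within 50000 nM to 200000 nM. The expected step of a number no higher from compound 2 to compound 3 (the limit leaves the size open) is essentially none.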

Compound 3, half-maximal cytotoxic concentration: > 100000 nM
Compound 3: only a limit was reported; the forecaster's own chance of this, stated with the estimate: 85%; the middle value lies on the limit itself.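

No step can be read from compound 1 or compound 2 to compound 3, since all three values are limits: the limit of > 100000 nM in this assay, at which 3 of the 3 values shown sit.

The compounds shown leave open whether hydrogen, methyl or chloro on the aromatic carbon makes any difference to the tolerated concentration.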